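This account rests on a few compounds, and the source may have more. Where it says the series, first, only, none or still open, it means among the compounds named here.

Measured so far, in a functional assay for agonist activity at Free fatty acid receptor 1 (Homo sapiens), read by FLIPR, in the presence of a further agent that is not named here; on this read-out higher numbers stand for an effect only at larger amounts of compound and lower numbers for an effect already at smaller amounts:
compound 1 `Cc1ccccc1Oc1ccc(CC2SC(=O)NC2=O)cc1` gives 124 nM;
compound 2 `Cc1ccc(Oc2ccc(CC3SC(=O)NC3=O)cc2)cc1` gives 547 nM;
compound 3 `O=C1NC(=O)C(Cc2ccc(Oc3ccc(F)cc3)cc2)S1` gives 480 nM.

Compound 2 stands at the highest number of the three. Its nearest neighbour is compound 3, the two lying within the scatter of each other, so nothing separates them; compound 1 lies further off, the step of a 4.4-fold higher number from compound 1 to compound 2 (0.64 log units; beyond the scatter) being beyond the scatter.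

Compound 4 `Cc1ccc(Oc2ccc(CC3SC(=O)NC3=O)cc2)c(C)c1` differs from compound 2 by methyl in place of hydrogen on an aromatic carbon. Among the compounds with values here, the step that bears on it is the one between compound 1 and compound 2: a 2-methylphenyl on the oxygen against a 4-methylphenyl, a 4.4-fold higher number from compound 1 to compound 2 (0.64 log units; beyond the scatter). Compound 4 carries both methyl groups at once, so the methyl of compound 1 is being restored on the scaffold of compound 2. On that basis a lower number in this assay is expected, of a size near the reverse of that step, with some uncertainty about how the two methyl groups combine. For compound 4 the estimate is 150 nM, between 60 nM and 400 nM, corresponding to an expected step of a 3.6-fold lower number from compound 2 to compound 4 (0.56 log units; beyond the scatter).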

Compound 4, half-maximal effective concentration: 121 nM
Compound 4: the middle estimate sits 1.2-fold (0.09 log units) above what was measured; the measured number falls inside the stated range.
By their numbers in this assay, from the lowest: compounds 4 and 1 (each within the scatter of the next); then compounds 3 and 2 (each within the scatter of the next).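

In this assay, a methyl in place of hydrogen ortho to a large group on compound 2 gives a step beyond the scatter (a 4.5-fold lower number from compound 2 to compound 4 (0.66 log units; beyond the scatter)), so this position still counts with the other methyl present. Within the data shown here, the second methyl on compound 1 gives a step within the scatter (a 1.0-fold lower number from compound 1 to compound 4 (0.01 log units; within the scatter)); the earlier compounds held one methyl or the other, and only this pair shows that the two together read the same as the single methyl of compound 1. Nothing measured here accounts for this difference between the two methyl groups.

On these data alone, it remains open whether a chloro or a methoxy at this same place would give a step like that of the methyl. As far as these compounds go, it is also open whether the methyl would do the same on compound 3, which carries a fluoro.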